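A few compounds are considered here, and "the series" means these few. Any claim that something is new, unique, unknown or untested is made for them only; others in the source may bear on it.

Measured compounds:
- Compound 1, `c1ccc(-c2nn3c(-c4ccncc4)nnc3s2)cc1`: 66.4%
- Compound 2, `c1ccc(Oc2nn3c(-c4ccncc4)nnc3s2)cc1`: 63.6%

In a functional assay on the whole organism for inhibition, with Rattus norvegicus as the target, read by paw edema, with a stated time of 4 h, at a dose of 70 mg/kg by the oral route (a lower number here means less inhibition, a higher number more inhibition at the dose given (going by the name of the read-out)), compound 1 gives 66.4%, and compound 2 gives 63.6%. Among the compounds with values here, the only measured step, phenoxy in place of phenyl on an aromatic carbon, is a number 2.8 percentage points lower from compound 1 to compound 2 (within the scatter), so the two numbers are not told apart; compound 1 merely carries the larger of the two figures.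

Compound 3, `O=[N+]([O-])c1ccc(-c2nn3c(-c4ccncc4)nnc3s2)cc1`, has not been measured in this assay. The change from compound 1 is nitro in place of hydrogen on an aromatic carbon. Within the data shown here, no measured step touches the para position of the phenyl ring, so nothing bears directly on this change; the one step measured, on a neighbouring part of the core, stayed within the scatter.

With no guidance in either direction, compound 3 is expected to give about 64%, between 45% and 80%, which means an estimated step of a number 2.4 percentage points lower from compound 1 to compound 3 (within the scatter).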

Compound 3, a percentage reported as inhibition, in the whole organism at one dose (the size of the read-out at that dose, not a potency): 86.3%
The estimate for compound 3 lay 22.3 percentage points below the measured number, and the stated range ends below it.
By their numbers in this assay, from the lowest: compounds 2 and 1 (each within the scatter of the next); then compound 3.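

In this assay, nitro in place of hydrogen on an aromatic carbon, para to a large group, comes with a number 19.9 percentage points higher from compound 1 to compound 3 (beyond the scatter), so this position responds to substitution in a way the phenoxy for phenyl change, which stayed within the scatter, did not show. A single group of 3 heavy atoms with no ring is enough to separate compound 3 from compound 1 in this read-out. No measurement at hand accounts for this step.

On these data alone, whether the rise belongs to nitro itself or to substitution at this carbon in general stays open; an amine, a methoxy group or a chlorine atom in the same place would tell these readings apart. Also open, as far as these compounds go, is whether nitro on another carbon of that ring, or at other oral doses, would give a similar result.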